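The source may hold more compounds than are shown below. What is called first, only, known or untested is meant among the compounds shown, and "the series" means these compounds.

Compound 1, whose structure is `CNC(=O)c1cc(Oc2ccc(C(=O)/C=C/c3cccc([N+](=O)[O-])c3)cc2)ccn1`, carries a 3-nitrophenyl group on the chain that links it to the shared core; in a functional assay on PC-3 cells (Homo sapiens) for cytotoxicity, read by MTT assay, with a stated time of 72 h (on this read-out lower numbers stand for stronger inhibition and higher numbers for weaker inhibition), compound 1 has "not determined" (no result reported), so where it stands on this read-out cannot be said. Two close relatives have been measured: compound 2, with the structure `CNC(=O)c1cc(Oc2ccc(C(=O)/C=C/c3ccc(F)cc3Cl)cc2)ccn1`, gives 4760 nM in this assay, and compound 3, with the structure `CNC(=O)c1cc(Oc2ccc(C(=O)/C=C/c3cc(OC)c(OC)c(OC)c3)cc2)ccn1`, gives 3150 nM. The two values lie within the usual scatter of each other. Compound 4, with the structure `CNC(=O)c1cc(Oc2ccc(C(=O)/C=C/c3ccc(F)cc3)cc2)ccn1`, differs from compound 1 in one place: 4-fluorophenyl in place of 3-nitrophenyl on a double-bonded chain carbon bound to a double-bonded chain carbon. Within the data shown here, since compound 1 has no number, no step can be sized; in this assay the change is expected to give a value close to those of compound 2 and compound 3. Compound 4 is expected to give about 5000 nM, with a range from 1500 nM to 16000 nM.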

Compound 4, half-maximal inhibitory concentration: 6140 nM
Compound 4: the middle estimate sits 1.2-fold (0.09 log units) below what was measured; the range from low to high includes it.
By their numbers in this assay, from the lowest: compounds 3, 2 and 4 (each within the scatter of the next).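

In this assay, hydrogen in place of chloro on an aromatic carbon gives a 1.3-fold higher number from compound 2 to compound 4 (0.11 log units; within the scatter) and so leaves the value within the scatter. On this phenyl ring, then, the chloro group of compound 2 can be lost without a measurable change, and the step from compound 1 to compound 4 still cannot be read. Nothing available here gives a reason for this result. Open, going by these compounds, is whether an amine or a carboxylic acid on this phenyl ring would shift the value beyond the scatter.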